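Fluoro for methoxy on the sulfanyl-linked ring

This account rests on a few compounds, and the source may have more. Where it says the series, first, only, none or still open, it means among the compounds named here.

Measured in a functional assay on A498 cells (Homo sapiens) for inhibition, read by sulforhodamine B assay, with a stated time of 48 h; on this read-out lower numbers stand for higher toxicity in this test and higher numbers for lower toxicity in this test:
- compound 1 `Nc1cc(N)c2nc(-c3ccccc3)c(Oc3ccc(Cl)c(Cl)c3)nc2c1`: < 100000 nM, reported only as an assay limit
- compound 2 `COc1ccc(Sc2nc3cc(N)cc(N)c3nc2-c2ccccc2)cc1`: 60300 nM

For the measured compounds named here, compound 2 holds the only number in this assay; the other value is a limit. Hence a step that the limit leaves unreadable from compound 1 to compound 2 cannot be read in size. Compound 3, `Nc1cc(N)c2nc(-c3ccccc3)c(Sc3ccc(F)cc3)nc2c1`, differs from compound 2 by fluoro in place of methoxy on an aromatic carbon. Going by the values given here, no measured step bears readably on this change, so no movement beyond the usual scatter is assumed, and the range is kept wide. Compound 3 is expected at 60000 nM, between 15000 nM and 200000 nM. The expected step is a 1.0-fold lower number from compound 2 to compound 3 (0.00 log units; within the scatter).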

Compound 3, concentration lethal to 50% of the cells: < 100000 nM
Compound 3: a limit, no number; the forecaster's own chance of this, stated with the estimate: 35%; the middle value is on the limit's open side.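

For the compounds shown here, compound 3 gives < 100000 nM as a limit and not a number, so no step among compound 1, compound 2 and compound 3 can be read. On these data alone, whether fluoro in place of methoxy shifts the toxicity read-out at all stays open.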